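Chloro in Place of Fluoro on a Shared Core

A few compounds are considered here, and "the series" means these few. Any claim that something is new, unique, unknown or untested is made for them only; others in the source may bear on it.

Compound 2 `CC1(C)CC(NC(=O)Nc2cccc(Cl)c2)c2cc(F)ccc2O1` was tested in a functional assay (aorta) with Rattus norvegicus as the target (on this read-out lower numbers stand for an effect already at smaller amounts and higher numbers for an effect only at larger amounts of compound), and gave only a limit of the assay, > 300000 nM. Compound 1 `Cc1cccc(NC(=O)NC2CC(C)(C)Oc3ccc(Cl)cc32)c1` likewise reached only a limit in this assay, > 10000 nM. Compound 2 therefore stands on no number, only at the limit of > 300000 nM in this assay, at which 1 of the 2 values shown sits. Compound 3 `CC1(C)CC(NC(=O)Nc2cccc(Cl)c2)c2cc(Cl)ccc2O1` carries chloro in place of fluoro on an aromatic carbon. Among the compounds with values here, no measured pair covers such a change, and the step expected, a number no higher from compound 2 to compound 3 (the limit leaves the size open), amounts to nothing beyond the usual scatter. Compound 3 is accordingly estimated at 300000 nM, with a range from 30000 nM to 3000000 nM, most probably again reported as a limit.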

Compound 3, half-maximal effective concentration: > 30000 nM
Compound 3: no number, only a limit; the forecaster's own chance of this, stated with the estimate: 85%; the middle value does not contradict the limit.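

Within the data shown here, compound 1, compound 2 and compound 3 all give only limits in this assay, so no step among them can be read. The compounds shown leave open whether chloro in place of fluoro on an aromatic carbon changes the effective concentration at all.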